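Taking the (furan-2-yl)carbonyl group off compound 3

The compounds below may be only part of what the source reports. "The series", "measured", "known", "first", "only" and "open" are said of these compounds alone.

- compound 1 `COc1cc(/C=C/C(=O)c2cccc(NC(=O)c3c(Cl)cccc3Cl)c2)ccc1O`: 1.58 ug/mL
- compound 2 `COc1cc(/C=C/C(=O)c2cccc(NC(=O)c3cccs3)c2)ccc1O`: 6.93 ug/mL
- compound 3 `COc1cc(/C=C/C(=O)c2cccc(NC(=O)c3ccco3)c2)ccc1O`: 5.46 ug/mL

In a functional assay on B16 cells (Mus musculus) for inhibition (on this read-out higher numbers stand for weaker inhibition and lower numbers for stronger inhibition), compound 3 gives 5.46 ug/mL. That puts it level with compound 2, within the scatter, while compound 1 has the lowest number of the three and so is the strongest inhibitor here.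

The next compound, compound 4 `COc1cc(/C=C/C(=O)c2cccc(N)c2)ccc1O`, differs from compound 3 in one place: hydrogen in place of (furan-2-yl)carbonyl on a nitrogen on an aromatic ring. In words, this is hydrogen in place of (furan-2-yl)carbonyl on a nitrogen on an aromatic ring, so ((furan-2-yl)carbonyl)amino becomes amino.

Going by the values given here, no measured step removes this whole group. The nearest evidence comes from swaps on the same carbonyl carbon. Two were modest, a 4.4-fold higher number from compound 1 to compound 2 (0.64 log units; beyond the scatter) and a 3.5-fold higher number from compound 1 to compound 3 (0.54 log units; beyond the scatter), and one stayed within the scatter, a 1.3-fold lower number from compound 2 to compound 3 (0.10 log units; within the scatter). Compound 4 loses the carbonyl as well, a larger change than any of these swaps, so its size is uncertain. The direction is also only a lean, taken from the two steps away from compound 1, which both raised the number.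

A modest move is expected, with a 1.6-fold higher number from compound 3 to compound 4 (0.22 log units; within the scatter) as the estimated step. For compound 4 the estimated value is 9 ug/mL, with an expected range from 2.5 ug/mL to 30 ug/mL.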

Compound 4, half-maximal inhibitory concentration: 11.5 ug/mL
Estimate against measurement, compound 4: 1.3-fold (0.11 log units) below; measured number inside the range.
By their numbers in this assay, from the lowest: compound 1; then compounds 3, 2 and 4 (each within the scatter of the next, the first and the last beyond it).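

Going by these compounds alone, this is the first look at the nitrogen with nothing on it, and in this assay the bare amino compound still gives a readable value, so inhibition on this read-out does not depend on a carbonyl-linked ring at this position. The two five-membered rings contribute little at most: taking off (furan-2-yl)carbonyl gives a 2.1-fold higher number from compound 3 to compound 4 (0.32 log units; beyond the scatter) and is only a modest change, while taking off (thiophen-2-yl)carbonyl gives a 1.7-fold higher number from compound 2 to compound 4 (0.22 log units; within the scatter) and leaves the number level. Only the (2,6-dichlorophenyl)carbonyl group stands clearly apart from the bare amine, with a 7.3-fold higher number from compound 1 to compound 4 (0.86 log units; beyond the scatter) on its removal, which shows that most of what this position can offer among these compounds belongs to that one group.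

Nothing measured here explains why that group differs from the other two, so the reason remains unknown. Still open, going by these compounds, is whether a plain benzoyl group without the two chlorine atoms would match it, and whether a small acetyl group or a simple methyl group on this nitrogen would sit nearer the bare amine or nearer compound 1.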